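The source may hold more compounds than are shown below. What is called first, only, known or untested is meant among the compounds shown, and "the series" means these compounds.

Compound 1 `C=C(Br)C(=O)Nc1cccc(-c2cn3nc(-c4ccccc4)sc3n2)c1` is the reference point of this pair. Among the compounds with values here, in a functional assay on CCRF-CEM cells (Homo sapiens) for inhibition, read by cell counting, with a stated time of 3 days (a higher number here means a weaker inhibitor, a lower number a stronger inhibitor), compound 1 gives 960 nM, the lower of the two numbers measured so far. Compound 2 `Nc1cccc(-c2cn3nc(-c4ccccc4)sc3n2)c1` carries hydrogen in place of the (1-bromoethenyl)carbonyl on the nitrogen on the aromatic ring, and in this assay compound 2 gives 33000 nM; the step of a 34-fold higher number from compound 1 to compound 2 (1.54 log units; beyond the scatter) is large. Compound 3 `C=C(Br)C(=O)Nc1cccc(-c2cn3nc(-c4ccc(Cl)cc4)sc3n2)c1` is not yet measured and differs from compound 1 in one place: chloro in place of hydrogen on an aromatic carbon The (1-bromoethenyl)carbonyl group that sets compound 1 apart from compound 2 is kept in compound 3. Within the data shown here, the only measured step concerns that group and not the phenyl ring, so no measured step bears on phenyl to 4-chlorophenyl, and the series offers no basis for a shift beyond the scatter in either direction. The step of a 1.1-fold lower number from compound 1 to compound 3 (0.03 log units; within the scatter) is therefore expected to stay within the scatter. Compound 3 is estimated at 900 nM, within 300 nM to 3000 nM.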

Compound 3, half-maximal inhibitory concentration: 3200 nM
The estimate for compound 3 lay 3.6-fold (0.55 log units) below the measured number; measured number outside the range, above it.
By their numbers in this assay, from the lowest: compound 1; then compound 3; then compound 2.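

In this assay, the phenyl ring is not a silent part of the series: chloro in place of hydrogen on this aromatic carbon gives a 3.3-fold higher number from compound 1 to compound 3 (0.52 log units; beyond the scatter), a modest step, whereas the earlier step concerned only the (1-bromoethenyl)carbonyl on the nitrogen. A single added heavy atom at this position, with the (1-bromoethenyl)carbonyl kept, is therefore enough to move the number beyond the scatter, in the direction of a weaker inhibitor. Nothing available explains this step.

Going by these compounds, whether the step belongs to chloro itself or to any substituent at this position remains open, and fluoro, methyl or methoxy in the same place would separate these readings. On these data alone, it is also open whether chloro has a comparable effect on the free amine of compound 2.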